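Estimating compound 4 from three growth inhibition values

This account rests on a few compounds, and the source may have more. Where it says the series, first, only, none or still open, it means among the compounds named here.

Compound 1 `CCCCn1cnc2c(NCc3cccc(Cl)c3)nc(N[C@H]3CC[C@H](N)CC3)nc21`: 350 nM
Compound 2 `CC(C)CCn1cnc2c(NCc3cccc(Cl)c3)nc(N[C@H]3CC[C@H](N)CC3)nc21`: 1330 nM
Compound 3 `CC(C)CCn1cnc2c(Nc3cccc(Cl)c3)nc(N[C@H]3CC[C@H](N)CC3)nc21`: 60 nM

These three compounds were tested in a functional assay on EOL1 cells (Homo sapiens) for inhibition, read by fluorescence, with a stated time of 72 h; on this read-out lower numbers stand for stronger inhibition of growth and higher numbers for weaker inhibition of growth. Among them, compound 1 stands in the middle at 350 nM, with a lower number than compound 2 and a higher number than compound 3.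

Compound 4 `CCCCn1cnc2c(Nc3ccccc3)nc(N[C@H]3CC[C@H](N)CC3)nc21` has not yet been measured. It differs from compound 1 in one place: phenyl in place of 3-chlorobenzyl on a nitrogen on an aromatic ring.

The closest evidence is a 22-fold lower number from compound 2 to compound 3 (1.35 log units; beyond the scatter), a large step that put 3-chlorophenyl in place of 3-chlorobenzyl on a nitrogen on an aromatic ring. Going by the values given here, that step kept the chlorine, whereas compound 4 has none, and no measured pair shows what losing the chlorine alone does. The step was also seen with a different chain. Among the compounds with values here, the only measured chain step, a 3.8-fold higher number from compound 1 to compound 2 (0.58 log units; beyond the scatter), is modest but beyond the scatter, so the large step need not carry over in full.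

A clearly lower number is therefore expected, though probably not the whole of the large step. In this assay the expected change is a 5.8-fold lower number from compound 1 to compound 4 (0.77 log units; beyond the scatter). For compound 4 the estimated value is 60 nM, with an expected range from 15 nM to 250 nM.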

Compound 4, concentration for 50% growth inhibition: 20 nM
Compound 4: middle estimate off by 3.0-fold (0.48 log units), on the high side; the measured number falls inside the stated range.
By their numbers in this assay, from the lowest: compound 4; then compound 3; then compound 1; then compound 2.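

In this assay, the change from 3-chlorobenzyl to phenyl on a nitrogen on an aromatic ring gave an 18-fold lower number from compound 1 to compound 4 (1.24 log units; beyond the scatter). A large step at this position therefore appears with the chain of compound 1 as well as with the chain of compound 2, where the closely related change gave a 22-fold lower number from compound 2 to compound 3 (1.35 log units; beyond the scatter); no compound shown goes against this, although the pattern rests on only these two pairs. The new result also shows that a low number here does not require the chlorine, as compound 4 carries none and still gives 20 nM. Nothing at hand explains why the phenyl and benzyl groups read so differently at this nitrogen.

The step to compound 4 removes the chlorine and changes benzyl to phenyl together, so the share of each remains open, and no pair shown isolates the effect of the chlorine on the phenyl ring. As far as these compounds go, it also remains open how a plain benzyl group, a methoxy group on the phenyl ring, or a longer chain would read in this assay.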